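This account rests on a few compounds, and the source may have more. Where it says the series, first, only, none or still open, it means among the compounds named here.

Series notes, metabolic stability

The series shares one core; compound 1 is `CCn1ncc2c(F)cc(-c3ccc(C(CC)(CC)c4nnc[nH]4)c(=O)[nH]3)cc21`, compound 2 is `CC(C)C(c1ccc(-c2ccc3cccc(F)c3c2)[nH]c1=O)N1CCCCC1=O`, compound 3 is `CCC(CC)(c1nnc[nH]1)c1ccc(-c2ccc3cccc(F)c3c2)[nH]c1=O`, and compound 4, not yet measured, is `CC(C)C(c1ccc(-c2ccc3cccc(F)c3c2)[nH]c1=O)N1CCNC1=O`. In an ADME assay on microsomes from liver (Rattus norvegicus) for metabolic stability (on this read-out lower numbers stand for a shorter-lived compound and higher numbers for a longer-lived compound), compound 1 gives > 3 h, which is a limit of this assay and not a number. In this assay compound 3 gives 0.925 h. In this assay compound 2 gives 0.102 h, the lower of the two numbers reported so far, with compound 3 the nearer of the other entries and its value beyond the scatter of compound 2. The single limit stands as the limit of > 3 h in this assay, at which 1 of the 3 values shown sits.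

Compound 4 differs from compound 2 in one place: 2-oxoimidazolidin-1-yl in place of 2-oxopiperidin-1-yl on a saturated chain carbon bound to an aromatic carbon and a saturated chain carbon. Within the data shown here, no measured pair of compounds carries this change, so there is nothing in hand to size it from. For compound 4 the step of a 2.5-fold higher number from compound 2 to compound 4 (0.39 log units; beyond the scatter) is expected, an increase in this assay that may or may not clear the scatter. The half-life of compound 4 in this assay is estimated at 0.25 h, with a range from 0.08 h to 0.8 h.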

Compound 4, half-life: 0.283 h
Compound 4: the middle estimate sits 1.1-fold (0.05 log units) below what was measured; the measured number falls inside the stated range.
By their numbers in this assay, from the lowest: compound 2; then compound 4; then compound 3. At a limit, above all of these: compound 1.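

In this assay, among these compounds, 2-oxoimidazolidin-1-yl in place of 2-oxopiperidin-1-yl gives a 2.8-fold higher number from compound 2 to compound 4 (0.44 log units; beyond the scatter), the first sized single-place change. This shows that the half-life responds to the group on this saturated chain carbon, although the step is modest. The change alters several things at once, replacing a six-membered ring with a five-membered ring, adding a second ring hetero atom and bringing in a hydrogen-bond donor, and nothing measured on these compounds accounts for the step.

As far as these compounds go, how the step divides among those features remains open; a 2-oxopyrrolidin-1-yl group at the same place would separate ring size from the added ring nitrogen. A methyl group on that nitrogen of 2-oxoimidazolidin-1-yl would test the part played by the donor.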